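The compounds below may be only part of what the source reports. "The series", "measured", "known", "first", "only" and "open" are said of these compounds alone.

The series turns on a single exchange made on two different cores. Compound 1 `C=C1[C@H](OC(C)=O)[C@@H](OC(C)=O)[C@@H](OC(C)=O)C(C)(C)/C=C/[C@H](C)[C@H](OC(=O)c2ccccc2)[C@@]2(O)C[C@@](C)(OC(C)=O)[C@H](OC(C)=O)[C@@H]2[C@H]1OCC(C)C` carries the first core, and in a toxicity assay on HEK-293T cells (Homo sapiens) for cytotoxicity, read by MTT assay, with a stated time of 48 h (on this read-out lower numbers stand for stronger inhibition and higher numbers for weaker inhibition), compound 1 gives 26100 nM. Compound 2 `C=C1[C@H](OC(C)=O)[C@@H](OC(C)=O)[C@@H](OC(C)=O)C(C)(C)/C=C/[C@H](C)[C@H](OC(=O)c2ccccc2)[C@@]2(O)C[C@@](C)(OC(=O)c3cccc(C)c3)[C@H](OC(C)=O)[C@@H]2[C@H]1OCC(C)C` differs from it in one place, (3-methylphenyl in place of methyl on a carbonyl carbon), and in this assay compound 2 gives 7220 nM. The step is a 3.6-fold lower number from compound 1 to compound 2 (0.56 log units; beyond the scatter).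

Compound 3 `C=C1[C@H](OC(C)=O)[C@@H](OC(C)=O)[C@@H](OC(C)=O)C(C)(C)/C=C/[C@H](C)[C@H]2O[C@]3(C)C[C@@]2(OC(=O)c2ccccc2)[C@H]([C@H]3OC(C)=O)[C@H]1OCC(C)C` has a second core; how it differs from the core of compound 1 is not broken down here. In this assay compound 3 gives 13500 nM, which sits within the usual scatter of the values of both compound 1 and compound 2, so no order among the three can be read from it.

Compound 4 `C=C1[C@H](OC(C)=O)[C@@H](OC(=O)c2cccc(C)c2)[C@@H](OC(C)=O)C(C)(C)/C=C/[C@H](C)[C@H]2O[C@]3(C)C[C@@]2(OC(=O)c2ccccc2)[C@H]([C@H]3OC(C)=O)[C@H]1OCC(C)C` stands to compound 3 as compound 2 stands to compound 1: the change is 3-methylphenyl in place of methyl on a carbonyl carbon, the same change, at a place described in the same words. For the measured compounds named here, since only one measured pair shows this change, the expectation rests on that pair alone. Because of a 3.6-fold lower number from compound 1 to compound 2 (0.56 log units; beyond the scatter), the step from compound 3 to compound 4 is expected to be of a similar size, a 3.4-fold lower number from compound 3 to compound 4 (0.53 log units; beyond the scatter), in this assay. On that basis compound 4 is expected to give about 4000 nM in this assay, with a likely range estimated from 1800 nM to 9000 nM.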

Compound 4, half-maximal inhibitory concentration: > 100000 nM
Compound 4: a limit, no number; the forecaster's own chance of this, stated with the estimate: 5%; middle value at least 25-fold (1.39 log units) away from the limit.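

In this assay compound 4 gives > 100000 nM, which is a limit of the assay and not a number: the limit of > 100000 nM in this assay, at which 1 of the 4 values shown sits. The exchange of methyl for 3-methylphenyl on a carbonyl carbon gives an at least 7.4-fold higher number from compound 3 to compound 4 (0.86 log units; beyond the scatter), so on this core it runs against the direction seen on the core of compound 1, and the change did not carry over from one core to the other: the same change on two cores in this assay, a 3.6-fold lower number (0.56 log units; beyond the scatter) from compound 1 to compound 2 and an at least 7.4-fold higher number (0.86 log units; beyond the scatter) from compound 3 to compound 4, at least 26-fold (1.42 log units) apart, beyond the scatter of two such steps. This shows that, in this series, a step seen on one core was no safe guide to the same change on the other, but it rests on a single pair for each core and does not show why the two steps part, nor whether the core itself or the particular acetoxy group exchanged decides the outcome.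

The compounds shown leave open whether a longer alkyl chain or a chain ending in an amine, placed on the same carbonyl carbon, would follow the step of compound 2 or that of compound 4. They also leave open what the 3-methylphenyl group does at each of the other acetoxy groups on either core, which would separate the effect of the core from that of the place.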